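Shifting the methoxy group on the amide-bound phenyl ring

The compounds below may be only part of what the source reports. "The series", "measured", "known", "first", "only" and "open" are said of these compounds alone.

Compound 1 `COc1ccc(Cl)cc1N(CC(=O)N1CCc2ccccc21)S(=O)(=O)c1ccccc1`: > 20000 nM (a limit of the assay)
Compound 2 `COc1ccc(NC(=O)CN(c2cc(Cl)ccc2OC)S(=O)(=O)c2ccccc2)cc1`: 16200 nM
Compound 3 `COc1cccc(NC(=O)CN(c2cc(Cl)ccc2OC)S(=O)(=O)c2ccccc2)c1`: 17600 nM

In a functional assay on SH-SY5Y cells (Homo sapiens), read by MTT assay, with a stated time of 24 h (a lower number here means that less compound is needed, a higher number that more compound is needed for the effect), compound 3 gives 17600 nM, the highest of the two real numbers, while compound 2 gives 16200 nM; the gap a 1.1-fold higher number from compound 2 to compound 3 (0.04 log units; within the scatter) lies within the scatter, so the two cannot be told apart. Compound 1 sits at the limit of > 20000 nM in this assay, at which 1 of the 3 values shown sits, which is a limit and not a number.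

Compound 4 `COc1ccccc1NC(=O)CN(c1cc(Cl)ccc1OC)S(=O)(=O)c1ccccc1` carries 2-methoxyphenyl in place of 3-methoxyphenyl on an amide-type nitrogen. Among the measured compounds shown here, the only measured step that bears on this kind of change is the one between compound 2 and compound 3, where the methoxyphenyl group on the amide nitrogen was exchanged for another methoxyphenyl group: a 1.1-fold higher number from compound 2 to compound 3 (0.04 log units; within the scatter), within the scatter. The steps of an at least 1.2-fold lower number from compound 1 to compound 2 (0.09 log units; that floor lies within the scatter) and an at least 1.1-fold lower number from compound 1 to compound 3 (0.05 log units; that floor lies within the scatter) start from a limit and say little. No shift beyond the scatter is therefore expected; the step of a 1.0-fold lower number from compound 3 to compound 4 (0.02 log units; within the scatter) is estimated to be small. Compound 4 is expected to give about 17000 nM, between 7000 nM and 40000 nM.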

Compound 4, half-maximal effective concentration: 15500 nM
Estimate against measurement, compound 4: 1.1-fold (0.04 log units) above; the range from low to high includes it.
By their numbers in this assay, from the lowest: compounds 4, 2 and 3 (each within the scatter of the next). At a limit, above all of these: compound 1.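

In this assay, the 2-methoxyphenyl group on the amide-type nitrogen adds a third placement of the methoxy group, and the readings show a 1.1-fold lower number from compound 3 to compound 4 (0.06 log units; within the scatter) and a 1.0-fold lower number from compound 2 to compound 4 (0.02 log units; within the scatter). Compounds 2, 3 and 4 therefore cannot be told apart, so among these three compounds, where the methoxy group sits on this ring makes no difference that this assay can detect. Compound 1 stands at a limit rather than at a number, so the steps from it, including an at least 1.2-fold lower number from compound 1 to compound 4 (0.11 log units; that floor lies within the scatter), cannot be read: the limit of > 20000 nM in this assay, at which 1 of the 4 values shown sits.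

From the compounds shown here alone, all three compounds that can be compared carry a methoxy group on this ring, so it remains open whether an amine, a carboxylic acid or a longer chain such as butoxy there would shift the number beyond the scatter. Going by these compounds, it is also open whether a ring without any substituent would give a similar number.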